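This account rests on a few compounds, and the source may have more. Where it says the series, first, only, none or still open, it means among the compounds named here.

Compound 1 `COc1cc2cc(Oc3ccc(NC(=O)Nc4cccc(C(F)(F)F)c4)cc3)c(C)nc2cc1OC` gives in a functional assay on DU-145 cells (Homo sapiens) for inhibition, read by sulforhodamine B assay, with a stated time of 48 h (on this read-out higher numbers stand for lower toxicity in this test and lower numbers for higher toxicity in this test), only a limit, > 50000 nM.
Compound 2 `COc1cc2cc(Oc3ccc(NC(=O)Nc4ccc(Cl)c(C(F)(F)F)c4)cc3)c(C)nc2cc1OC` gives in this assay 19100 nM.

Compound 2 thus holds the only actual number shown; the other value is a limit. Compound 3 `COc1cc2cc(Oc3ccc(NC(=O)Nc4ccc(Cl)c(Cl)c4)cc3)c(C)nc2cc1OC` differs from compound 2 by chloro in place of trifluoromethyl on an aromatic carbon. Among the compounds with values here, the one measured step, an at least 2.6-fold lower number from compound 1 to compound 2 (0.41 log units; beyond the scatter), added chloro in place of hydrogen on the same ring and moved the number out of the limit region the limit of > 50000 nM in this assay, at which 1 of the 2 values shown sits, into a measurable value. Within the data shown here, that step does not exchange trifluoromethyl for chloro, so no measured step bears directly on the change to compound 3; any guidance is indirect. A small step, within or only just beyond the scatter, is therefore expected in this assay, with the direction uncertain. For compound 3 the estimated value is 25000 nM, within 10000 nM to 60000 nM, which means an expected step of a 1.3-fold higher number from compound 2 to compound 3 (0.12 log units; within the scatter).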

Compound 3, concentration lethal to 50% of the cells: 68400 nM
The estimate for compound 3 lay 2.7-fold (0.44 log units) below the measured number, outside the stated range (above it).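

On an aromatic carbon ortho to a chloro group, putting chloro in place of trifluoromethyl gives a 3.6-fold higher number from compound 2 to compound 3 (0.55 log units; beyond the scatter) in this assay, so on this read-out the change goes with lower toxicity in this test. The earlier step showed only what adding chloro to the ring did; this one shows that chloro does not set the number alone, since it stays in place while the neighbouring group still matters. The step between compound 1 and compound 3 cannot be read because compound 1 gives only a limit: the limit of > 50000 nM in this assay, at which 1 of the 3 values shown sits.

The compounds shown leave open how other groups at this place, such as methyl, methoxy, a nitrile or an amine, would read. They also leave open whether the same exchange would give a similar step without the chloro group on the ring.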